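This account rests on a few compounds, and the source may have more. Where it says the series, first, only, none or still open, it means among the compounds named here.

Three compounds share a core in which a carbonyl carbon hangs on a double-bonded ring carbon, and they differ only in what that carbonyl carries. Compound 1 `CC(=O)C1=C(C)NC(=O)NC1c1ccoc1` carries a methyl, compound 2 `CC1=C(C(=O)CC(C)C)C(c2ccoc2)NC(=O)N1` an isobutyl, and compound 3 `CC1=C(C(=O)NC(C)C)C(c2ccoc2)NC(=O)N1` an isopropylamino. In an assay on membranes from HeLa cells for displacement of a labelled ligand from adenosine receptor A3 (Homo sapiens), read by scintillation counting, with a stated time of 180 min, tested at 1 uM (a lower number here means less inhibition, a higher number more inhibition at the concentration tested (going by the name of the read-out)), compound 1 gives 2%, compound 2 gives 18% and compound 3 gives 3%. Compound 3 thus sits second of the three, close to compound 1 and well apart from compound 2, which lies above it by the step of a number 15 percentage points lower from compound 2 to compound 3 (beyond the scatter); the step of a number 1 percentage points higher from compound 1 to compound 3 (within the scatter) stays within the scatter.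

Compound 4 `CC1=C(C(=O)OC2CCC2)C(c2ccoc2)NC(=O)N1` changes the same carbonyl: cyclobutyloxy in place of isopropylamino on a carbonyl carbon. Neither measured step swaps an amine for an alkoxy group, so the steps of a number 16 percentage points higher from compound 1 to compound 2 (beyond the scatter) and a number 15 percentage points lower from compound 2 to compound 3 (beyond the scatter) bear on it only loosely, by showing that this position moves the read-out modestly at best. Compound 4 is therefore expected to move by a number 6 percentage points higher from compound 3 to compound 4 (within the scatter), and its value in this assay is estimated at 9%, between 0% and 25%.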

Compound 4, a percentage reported as inhibition, at one concentration (the size of the read-out at that concentration, not a potency): 1%
Beside the measured number, compound 4's estimate is 8 percentage points above it; measured number inside the range.
By their numbers in this assay, from the lowest: compounds 4, 1 and 3 (each within the scatter of the next); then compound 2.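

In this assay, putting cyclobutyloxy in place of isopropylamino on the carbonyl carbon gives a number 2 percentage points lower from compound 3 to compound 4 (within the scatter), and the comparison with the methyl gives a number 1 percentage points lower from compound 1 to compound 4 (within the scatter). The earlier compounds had shown this only for an isopropylamino group, so a carbonyl carrying an oxygen-linked four-membered ring now joins the methyl and the isopropylamino in the same narrow range. Against the isobutyl there is a number 17 percentage points lower from compound 2 to compound 4 (beyond the scatter), which leaves compound 2 as the only one of the four set apart.

Going by these compounds, whether that higher number extends to other carbon chains on the carbonyl, such as a butyl or a cyclobutyl group, stays open, as does whether a cyclobutylamino or a simple ethoxy group would read like compound 4. Nothing at hand gives a reason for the isobutyl standing apart.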